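From a Carboxamide Tail to a Phosphate Ester

This account rests on a few compounds, and the source may have more. Where it says the series, first, only, none or still open, it means among the compounds named here.

Compound 1 `CCOc1cc(NC(=O)C2(NC(=O)c3ccc4c(C5CCCC5)c(-c5ncc(Cl)cn5)n(C)c4c3)CCC2)ccc1/C=C/C(=O)N[C@@H](CC(=O)O)C(N)=O` stands at a limit: in an ADME assay on stomach for pharmacokinetics, in simulated gastric fluid (a higher number here means that the compound lasts longer, a lower number that the compound disappears faster), compound 1 gives > 5 h, which is a limit of the assay (the limit of > 5 h in this assay, at which 1 of the 3 values shown sits). Compound 2 `CCOc1cc(NC(=O)C2(NC(=O)c3ccc4c(C5CCCC5)c(-c5ncc(Cl)cn5)n(C)c4c3)CCC2)ccc1/C=C/C(=O)N[C@@H](CCC(=O)O)C(N)=O` gives 0.533 h in this assay. Compound 3 `CCOc1cc(NC(=O)C2(NC(=O)c3ccc4c(C5CCCC5)c(-c5ncc(Cl)cn5)n(C)c4c3)CCC2)ccc1/C=C/C(=O)N[C@@H](CCCNC(=N)N)C(N)=O` gives 0.467 h in this assay. The two measured steps out of compound 1, an at least 9.3-fold lower number from compound 1 to compound 2 (0.97 log units; beyond the scatter) and an at least 10-fold lower number from compound 1 to compound 3 (1.02 log units; beyond the scatter), both alter the chain carrying the carboxy group, whereas compound 4 `CCOc1cc(NC(=O)C2(NC(=O)c3ccc4c(C5CCCC5)c(-c5ncc(Cl)cn5)n(C)c4c3)CCC2)ccc1/C=C/C(=O)OCOP(=O)(O)O` changes the carbonyl carbon itself: a group of 7 heavy atoms (1 carbon, 5 oxygen, 1 phosphorus; no ring) in place of a group of 9 heavy atoms (4 carbon, 2 nitrogen, 3 oxygen; no ring), on a carbonyl carbon. Among the compounds with values here, no measured step touches that position, so the known steps bear only loosely on it. A decrease is nonetheless expected, an at least 3.3-fold lower number from compound 1 to compound 4 (0.52 log units; beyond the scatter), and compound 4 is estimated at 1.5 h with a range from 0.3 h to 6 h.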

Compound 4, half-life: 1.3 h
For compound 4 the middle estimate is 1.2-fold (0.06 log units) above the measured one; the range from low to high includes it.
By their numbers in this assay, from the lowest: compounds 3 and 2 (each within the scatter of the next); then compound 4. At a limit, above all of these: compound 1.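

At the carbonyl carbon itself, the phosphate ester in place of the (1-carbamoyl-2-carboxyethyl)amino group changes the result in this assay: an at least 3.8-fold lower number from compound 1 to compound 4 (0.58 log units; beyond the scatter). The number for compound 1 is a limit: the limit of > 5 h in this assay, at which 1 of the 4 values shown sits. The same position also separates compound 4 from both chain variants, with a 2.8-fold higher number from compound 3 to compound 4 (0.44 log units; beyond the scatter) and a 2.4-fold higher number from compound 2 to compound 4 (0.39 log units; beyond the scatter). The compounds shown do not tell whether the entering phosphate ester or the departing (1-carbamoyl-2-carboxyethyl)amino group sets this number. From the compounds shown here alone, how a carboxylic acid or a methyl ester on this carbonyl carbon would compare remains open.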